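The compounds below may be only part of what the source reports. "The series", "measured", "known", "first", "only" and "open" are said of these compounds alone.

Measured in a functional assay on MDA-MB-231 cells (Homo sapiens) for cytotoxicity, read by MTT assay, with a stated time of 48 h; on this read-out higher numbers stand for weaker inhibition and lower numbers for stronger inhibition:
Compound 1 `O=C(NCCCCC(c1ccc(F)cc1)c1ccc(F)cc1)Nc1ccc(I)cc1`: 11800 nM
Compound 2 `Nc1cc(NC(=O)NCCCCC(c2ccc(F)cc2)c2ccc(F)cc2)ccc1Cl`: 9240 nM

Compound 2, at 9240 nM, cannot be told apart from the other measured compound. Compound 3 `O=C(NCCCCC(c1ccc(F)cc1)c1ccc(F)cc1)Nc1ccc(Br)cc1I` remains unmeasured and differs from compound 2 as follows: 4-bromo-2-iodophenyl in place of 3-amino-4-chlorophenyl on an amide-type nitrogen. Among the compounds with values here, only one measured step bears on this change, the exchange of 4-iodophenyl for 3-amino-4-chlorophenyl on the same amide-type nitrogen, a 1.3-fold lower number from compound 1 to compound 2 (0.11 log units; within the scatter). No step beyond the scatter is therefore expected in this assay, in either direction. The estimate implies an expected step of a 1.1-fold higher number from compound 2 to compound 3 (0.03 log units; within the scatter). For compound 3, the estimated value is 10000 nM, with an expected range of 4000 nM to 25000 nM.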

Compound 3, half-maximal inhibitory concentration: > 20000 nM
Compound 3 was reported as a limit (the forecaster's own chance of this, stated with the estimate: 8%); middle value at least 2.0-fold (0.30 log units) away from the limit.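

In this assay, the exchange at this amide-type nitrogen now separates two compounds: 4-bromo-2-iodophenyl in place of 3-amino-4-chlorophenyl gives an at least 2.1-fold higher number from compound 2 to compound 3 (0.33 log units; beyond the scatter), whereas the earlier step stayed within the scatter. Replacing 4-iodophenyl with the same group gives an at least 1.6-fold higher number from compound 1 to compound 3 (0.22 log units; that floor lies within the scatter), so this comparison does not separate those two compounds. Compound 3 is reported only as a limit: the limit of > 20000 nM in this assay, at which 1 of the 3 values shown sits.

From the compounds shown here alone, how far compound 3 lies past that limit remains open. Also open, going by these compounds, is whether a lone amine or a lone chlorine on the phenyl ring would match compound 2.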